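From compound 3 to compound 4 at the limit

The source may report more compounds than this note shows. Statements on the series, on what has been measured and on what is new or still open speak of the compounds shown alone.

In an ADME assay on THP-1 cells (Homo sapiens) for cytotoxicity, read by flow cytometry and propidium iodide staining, with a stated time of 72 h (a higher number here means a weaker inhibitor, a lower number a stronger inhibitor), compound 1 `CC(=O)Nc1ccc2oc(-c3ccccc3)c(O)c(=O)c2c1` gives 36000 nM as its reading. Compound 2 `COc1ccccc1-c1oc2ccc(NC(C)=O)cc2c(=O)c1O` shows > 125000 nM as a limit of the assay. Compound 3 `COc1c(-c2ccccc2)oc2ccc(NC(C)=O)cc2c1=O` shows > 125000 nM as a limit too, so it has no exact number. Compound 4 `COc1ccccc1-c1oc2ccc(NC(C)=O)cc2c(=O)c1OC` differs from compound 3 by methoxy in place of hydrogen on an aromatic carbon with phenyl becoming 2-methoxyphenyl. That same replacement gave an at least 3.4-fold higher number from compound 1 to compound 2 (0.54 log units; beyond the scatter) as its step. Methyl in place of hydrogen on the oxygen gave an at least 3.4-fold higher number from compound 1 to compound 3 (0.54 log units; beyond the scatter) as the other step. Both steps raise the number, so a further rise is expected, which is a step that the limit leaves unreadable from compound 3 to compound 4 as estimated. Compound 4 is estimated at 180000 nM within an expected range of 80000 nM to 400000 nM in this assay and will probably be reported only as a limit.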

Compound 4, half-maximal inhibitory concentration: 108000 nM
Compound 4: middle estimate off by 1.7-fold (0.22 log units), on the high side, and the stated range covers the measured number.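

In this assay, methoxy in place of hydrogen on the aromatic carbon gives an at least 1.1-fold lower number from compound 3 to compound 4 (0.06 log units; that floor lies within the scatter), and methyl in place of hydrogen on the oxygen gives an at least 1.1-fold lower number from compound 2 to compound 4 (0.06 log units; that floor lies within the scatter), so neither change repeats the clear rise it gave on compound 1. The methoxy change therefore reads differently on the two cores: the same change on two cores in this assay, an at least 3.4-fold higher number (0.54 log units; beyond the scatter) from compound 1 to compound 2 and an at least 1.1-fold lower number (0.06 log units; that floor lies within the scatter) from compound 3 to compound 4, at least 4.0-fold (0.60 log units) apart, beyond the scatter of two such steps The methyl change does the same: the same change on two cores in this assay, an at least 3.4-fold higher number (0.54 log units; beyond the scatter) from compound 1 to compound 3 and an at least 1.1-fold lower number (0.06 log units; that floor lies within the scatter) from compound 2 to compound 4, at least 4.0-fold (0.60 log units) apart, beyond the scatter of two such steps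

Going by these compounds, the true size of both new steps stays open, since compound 2 and compound 3 are known only as limits: the limit of > 125000 nM in this assay, at which 2 of the 4 values shown sit. Also open is how an amine in place of the methoxy would read in this assay.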